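From 4-chlorophenyl to 1,3-thiazol-2-yl on the amide nitrogen

A few compounds are considered here, and "the series" means these few. Any claim that something is new, unique, unknown or untested is made for them only; others in the source may bear on it.

Of the compounds shown here, three have been read so far in a functional assay on HCT-116 cells (Homo sapiens) for inhibition, read by colorimetric assay, with a stated time of 3 days; a lower number here means a stronger inhibitor, a higher number a weaker inhibitor. Compound 3 `O=C(CCCCCCNC(=O)C(O)(O)C(F)(F)F)Nc1ccc(Cl)cc1` gives 4230 nM. Compound 1 `CCOc1ccc(-c2cnc(NC(=O)CCCCCCNC(=O)C(O)(O)C(F)(F)F)s2)cc1` gives 4050 nM, within the scatter of compound 3. Compound 2 `O=C(CCCCCCNC(=O)C(O)(O)C(F)(F)F)Nc1c(F)cc(F)cc1F` gives 22200 nM, the highest number of the three, so compound 3 sits at the lower end of the series, level with compound 1.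

Compound 4 `O=C(CCCCCCNC(=O)C(O)(O)C(F)(F)F)Nc1nccs1` carries 1,3-thiazol-2-yl in place of 4-chlorophenyl on an amide-type nitrogen whose other neighbour is the carbonyl carbon: 1,3-thiazol-2-yl in place of 4-chlorophenyl on an amide-type nitrogen.

Among the measured compounds shown here, only one measured step changes this same place: a 5.2-fold lower number from compound 2 to compound 3 (0.72 log units; beyond the scatter). That step involves a different leaving group, so it shows that a change here can shift the number by a modest amount, but it sets no direction for the entering group. No measured number in this assay lies clearly under that of compound 3 at 4230 nM, so a move upward of modest size is the more likely outcome, though no change beyond the scatter remains possible. The expected change is a 2.1-fold higher number from compound 3 to compound 4 (0.33 log units; beyond the scatter). The estimate for compound 4 is 9000 nM, with an expected range of 3500 nM to 25000 nM.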

Compound 4, half-maximal inhibitory concentration: 10800 nM
Compound 4: middle estimate off by 1.2-fold (0.08 log units), on the low side, and the stated range covers the measured number.
By their numbers in this assay, from the lowest: compounds 1 and 3 (each within the scatter of the next); then compound 4; then compound 2.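

In this assay, 1,3-thiazol-2-yl on the amide-type nitrogen is not an even exchange for 4-chlorophenyl, with a 2.6-fold higher number from compound 3 to compound 4 (0.41 log units; beyond the scatter) as the first measured step away from that group in the upward direction. The same group stands apart from 2,4,6-trifluorophenyl as well, with a 2.1-fold lower number from compound 2 to compound 4 (0.31 log units; beyond the scatter) on record, so the three groups at this place now give three separate levels, and the unsubstituted ring takes the middle one. The series also gains its first read on the aromatic carbon of the thiazole, where a 2.7-fold higher number from compound 1 to compound 4 (0.43 log units; beyond the scatter) shows that removing 4-ethoxyphenyl costs about as much as the exchange for 4-chlorophenyl, and that a group at this carbon brings the number back within the scatter of compound 3.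

As far as these compounds go, it remains open whether that recovery needs the whole 4-ethoxyphenyl group or only a plain phenyl ring, and whether a small substituent such as a methyl group, an amine or a carboxylic acid at the same carbon would act alike. Whether a longer chain in the shared core would move these numbers also stays unanswered. No independent measurement of any property accompanies these results, so the steps stand here as numbers alone.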